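Sulfonyl group exchange from compound 3 to compound 4

The source may report more compounds than this note shows. Statements on the series, on what has been measured and on what is new or still open speak of the compounds shown alone.

Values in an ADME assay on microsomes (Mus musculus) for metabolic stability (on this read-out higher numbers stand for fast clearance and lower numbers for slow clearance), so far:
- compound 1 `Cc1cc(C(F)(F)F)c2cccc(OCc3c(Cl)ccc(S(=O)(=O)N4CCC[C@H]4CO)c3Cl)c2n1` gives 1630 mL/min/kg
- compound 2 `COC[C@@H]1CCCN1S(=O)(=O)c1ccc(Cl)c(COc2cccc3c(C(F)(F)F)cc(C)nc23)c1Cl` gives 1620 mL/min/kg
- compound 3 `Cc1cc(C(F)(F)F)c2cccc(OCc3c(Cl)ccc(S(=O)(=O)N4CC[C@@H](N(C)C)C4)c3Cl)c2n1` gives 867 mL/min/kg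

Compound 3 lies within the scatter of both compound 1 and compound 2, so the three values show no order. Next is compound 4 `Cc1cc(C(F)(F)F)c2cccc(OCc3c(Cl)ccc(S(=O)(=O)N4C[C@@H](C)O[C@@H](C)C4)c3Cl)c2n1` with the change 2,6-dimethylmorpholin-4-yl in place of 3-(dimethylamino)pyrrolidin-1-yl on a sulfonyl sulfur on a sulfonyl sulfur. Two measured steps exchange the group at this place (a 1.9-fold lower number from compound 1 to compound 3 (0.27 log units; within the scatter) and a 1.9-fold lower number from compound 2 to compound 3 (0.27 log units; within the scatter)) and both stay within the scatter, as does the smaller edit (a 1.0-fold lower number from compound 1 to compound 2 (0.00 log units; within the scatter)). None of these steps introduces 2,6-dimethylmorpholin-4-yl, so the basis is thin. The estimated step is a 1.5-fold higher number from compound 3 to compound 4 (0.18 log units; within the scatter) and no shift beyond the scatter is expected. In this assay the estimated value for compound 4 is 1300 mL/min/kg (expected range 650 mL/min/kg to 2400 mL/min/kg).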

Compound 4, clearance: 933 mL/min/kg
Beside the measured number, compound 4's estimate is 1.4-fold (0.14 log units) above it; the range from low to high includes it.
By their numbers in this assay, from the lowest: compounds 3, 4, 2 and 1 (each within the scatter of the next).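

In this assay, 2,6-dimethylmorpholin-4-yl on the sulfonyl sulfur stays within the scatter of all three earlier groups (a 1.1-fold higher number from compound 3 to compound 4 (0.03 log units; within the scatter)) (a 1.7-fold lower number from compound 2 to compound 4 (0.24 log units; within the scatter)) (a 1.7-fold lower number from compound 1 to compound 4 (0.24 log units; within the scatter)). A six-membered non-aromatic ring with 2 hetero atoms therefore reads the same here as the five-membered rings, so this position has still produced no step beyond the scatter. No measured data bear on why these values stay together. Still open, from the compounds shown here alone, is whether a carboxylic acid or an open-chain amine on the sulfonyl sulfur would produce a step beyond the scatter. Changes elsewhere on the shared core also remain open.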